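Cytotoxicity Expectation for a Fluoro Swap on the Pyridine

The source may report more compounds than this note shows. Statements on the series, on what has been measured and on what is new or still open speak of the compounds shown alone.

In an ADME assay on HepG2 2.2.15 cells (Homo sapiens) for cytotoxicity, read by MTT assay, with a stated time of 8 days (a lower number here means that less compound is tolerated, a higher number that more compound is tolerated), compound 1 (`CC(C)c1cc(-c2ccc(F)nc2F)nn(Cc2ccc(Cl)cc2)c1=O`) gives 56700 nM as its half-maximal cytotoxic concentration. Compound 2 (`CN(C)c1ccc(-c2nn(Cc3ccc(C#N)cc3)c(=O)c3ccccc23)c(F)n1`) gives 79200 nM in the same read-out, and the two numbers lie within the scatter of each other, so compound 2 stands level with compound 1 on the numbers shown. Compound 3 (`N#Cc1ccc(Cn2nc(-c3cc(Cl)c(NC[C@@H](O)CO)nc3F)c3ccccc3c2=O)cc1`) reads > 100000 nM as a limit of the assay and not a number.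

Compound 4 (`N#Cc1ccc(Cn2nc(-c3ccc(F)nc3F)c3ccccc3c2=O)cc1`) has not yet been measured. The change from compound 2 to compound 4 is fluoro in place of dimethylamino on an aromatic carbon and in words it is fluoro in place of dimethylamino on an aromatic carbon, next to the ring nitrogen, with 6-(dimethylamino)-2-fluoropyridin-3-yl becoming 2,6-difluoropyridin-3-yl.

Among the compounds with values here, no step between measured compounds differing in one place is available in this assay to size this change. Within the data shown here, with compound 1 at 56700 nM and compound 2 at 79200 nM as the only numbers, no shift beyond the scatter is expected in either direction. The estimated change is a 1.3-fold lower number from compound 2 to compound 4 (0.12 log units; within the scatter) and it stays within the scatter. For compound 4 the expected half-maximal cytotoxic concentration is 60000 nM with an estimated range from 25000 nM to 100000 nM in this series.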

Compound 4, half-maximal cytotoxic concentration: > 100000 nM
Compound 4 ended at the assay's limit; the forecaster's own chance of this, stated with the estimate: 30%; middle value at least 1.6-fold (0.22 log units) away from the limit.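

In this assay compound 4 reads > 100000 nM, which is a limit of the assay and not a number. The exchange of dimethylamino for fluoro on this aromatic carbon, next to the ring nitrogen, now has its first step in the series, an at least 1.2-fold higher number from compound 2 to compound 4 (0.10 log units; that floor lies within the scatter), and that figure is only a floor, so the true size of the change is not fixed. What this adds is one-sided: the 2,6-difluoropyridin-3-yl compound shows no sign of a lower number than the 6-(dimethylamino)-2-fluoropyridin-3-yl compound, so at this position dimethylamino is not needed for the compound to be tolerated, and the read-out gives no further detail on this side: the limit of > 100000 nM in this assay, at which 2 of the 4 values shown sit.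

On these data alone, whether the real gap between these two compounds lies beyond the scatter remains open, since only a floor within the scatter is available. Also open, as far as these compounds go, is how a morpholine, a methoxy group or a longer alkyl amine on this same carbon would read, and whether any of these would give a number or reach the same limit.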